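This account rests on a few compounds, and the source may have more. Where it says the series, first, only, none or still open, it means among the compounds named here.

Three compounds have values so far in an ADME assay on L6 cells (Rattus norvegicus) for inhibition, read by resazurin assay, with a stated time of 72 h (on this read-out lower numbers stand for stronger inhibition and higher numbers for weaker inhibition), and they read as follows
Compound 1 `CSC[C@H]1O[C@@H](n2cnc3c(N)nc(Cl)nc32)[C@H](OC(C)=O)[C@@H]1OC(C)=O` gives 216000 nM
Compound 2 `C[S+]([O-])C[C@H]1O[C@@H](n2cnc3c(N)nc(Cl)nc32)[C@H](O)[C@@H]1O` gives 259000 nM
Compound 3 `CC(=O)O[C@@H]1[C@H](OC(C)=O)[C@@H](CN=[N+]=[N-])O[C@H]1n1cnc2c(N)nc(F)nc21` gives 18000 nM

Compound 1 sits at the high end of these numbers, within the scatter of compound 2. Compound 3 has a lower number than compound 1, and that gap lies beyond the scatter.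

Compound 4 `CC(=O)NC[C@H]1O[C@@H](n2cnc3c(N)nc(Cl)nc32)[C@H](OC(C)=O)[C@@H]1OC(C)=O` has not yet been measured. It carries acetamido in place of the methylsulfanyl of compound 1, on a saturated chain carbon bound to a saturated ring carbon acetamido in place of methylsulfanyl on a saturated chain carbon bound to a saturated ring carbon and the rest of the structure stays the same. Going by the values given here, no measured pair differs in one place only, so the data offer no direct guide to this change. Compound 3 differs from compound 1 in more than one place and cannot serve as one either. In this assay no step beyond the scatter is therefore expected, with only a slight lean towards a lower number. The expectation rests on compound 1 at 216000 nM as its anchor. The estimated change is a 1.4-fold lower number from compound 1 to compound 4 (0.16 log units; within the scatter) and it stays within the scatter. For compound 4 the estimated value is 150000 nM with an expected range from 40000 nM to 320000 nM on this read-out.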

Compound 4, half-maximal inhibitory concentration: 190000 nM
Beside the measured number, compound 4's estimate is 1.3-fold (0.10 log units) below it; measured number inside the range.
By their numbers in this assay, from the lowest: compound 3; then compounds 4, 1 and 2 (each within the scatter of the next).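

In this assay, the comparison of a single change at this position is a 1.1-fold lower number from compound 1 to compound 4 (0.06 log units; within the scatter), with acetamido in place of methylsulfanyl on a saturated chain carbon bound to a saturated ring carbon. This exchange replaces a group with no hydrogen-bond donor by one that carries a hydrogen-bond donor and a double bond outside aromatic rings, yet the two numbers stay within the scatter of each other, so this read-out does not separate the two groups at this position. Nothing available accounts for this outcome.

The compounds shown leave open whether an amine, a carboxylic acid or a longer chain at this same position would also stay within the scatter of compound 1, or whether a group of another kind would shift the number beyond it. They also leave unassigned the lower number of compound 3, which differs from compound 1 in more than one place, so no single change can be credited with that gap.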